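Swapping methoxy for tert-butyl on a potent EP4 antagonist

The source may report more compounds than this note shows. Statements on the series, on what has been measured and on what is new or still open speak of the compounds shown alone.

Of the compounds shown here, three that share one core have been measured in a functional assay on CHO/Galpha16 cells for antagonist activity at prostaglandin E2 receptor EP4 subtype (Homo sapiens), read by calcium flux, with a stated time of 15 min; on this read-out higher numbers stand for weaker inhibition and lower numbers for stronger inhibition. Compound 1 `C[C@H](NC(=O)c1c(CCc2ccc(F)cc2)sc2c1CC(C)(C)OC2)c1ccc(C(=O)O)cc1` gives 36.2 nM, and compound 2 `O=C(NCC1CCC(C(=O)O)CC1)c1c(Cc2ccc(F)cc2)sc2c1CCOC2` gives 30.3 nM. Compound 3 `COc1ccc(Cc2sc3c(c2C(=O)N[C@@H](C)c2ccc(C(=O)O)cc2)CCOC3)cc1` gives 2.1 nM, the lowest of the three numbers; its gaps to compound 2 and to compound 1 both lie beyond the usual scatter, so compound 3 is the strongest inhibitor among the measured compounds.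

Compound 4 `C[C@H](NC(=O)c1c(Cc2ccc(C(C)(C)C)cc2)sc2c1CCOC2)c1ccc(C(=O)O)cc1` has not yet been measured. It differs from compound 3 in one place: tert-butyl in place of methoxy on an aromatic carbon. The change sits on an aromatic carbon of a six-membered aromatic ring of carbon only, where methoxy leaves and tert-butyl enters. For the measured compounds named here, no pair of measured compounds shows this same change, so the size of the step cannot be read from any earlier example.

Without such a precedent, a modest weakening is expected rather than a large one, because compound 3 already sits at 2.1 nM and the change touches only a small substituent. The expected step of a 2.9-fold higher number from compound 3 to compound 4 (0.46 log units; beyond the scatter) is therefore estimated as a small loss that may or may not exceed the scatter. For compound 4 the estimate in this assay is 6 nM, with a plausible range from 1.5 nM to 25 nM.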

Compound 4, half-maximal inhibitory concentration: 9.5 nM
Compound 4: the middle estimate sits 1.6-fold (0.20 log units) below what was measured; the measured number falls inside the stated range.
By their numbers in this assay, from the lowest: compound 3; then compound 4; then compounds 2 and 1 (each within the scatter of the next).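

In this assay, for the compounds shown here, tert-butyl in place of methoxy gives a 4.5-fold higher number from compound 3 to compound 4 (0.66 log units; beyond the scatter), the first direct reading of how this aromatic carbon, para to a large group, responds to a change of substituent. The step is modest but beyond the scatter, so the group at this place does affect the read-out, yet a larger group with no hydrogen-bond acceptor is accepted with only a limited loss. This single pair cannot separate the two differences, since methoxy has 2 heavy atoms and 1 hydrogen-bond acceptor whereas tert-butyl has 4 heavy atoms and none, and no data on hand account for the size of the step.

The compounds shown leave open where a methyl group, a chlorine atom or an ethoxy group at this same carbon would fall relative to methoxy and tert-butyl, which could help show whether size or the oxygen matters more. They also leave open whether this swap would produce a similar step with a longer chain joining this aromatic ring to the shared core.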